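Ester to Acid on an Inactive Thiophene Anilide

A few compounds are considered here, and "the series" means these few. Any claim that something is new, unique, unknown or untested is made for them only; others in the source may bear on it.

Measured compounds:
Compound 1 `COC(=O)c1c(Nc2ccc(OC)cc2)sc(C(=O)c2ccc(OC)cc2)c1C`: 15.5%
Compound 2 `COC(=O)c1c(Nc2ccc(Cl)cc2)sc(C(=O)c2ccc(OC)cc2)c1C`: "not active" (no number reported)

In a functional assay, with a stated time of 150 min, tested at 25 ug/mL (a lower number here means a weaker effect, a higher number a stronger effect of the compound at the concentration tested), compound 1 gives 15.5%, a weak effect. In this assay compound 2 is reported as "not active" (no number reported), so no number marks where it stands; only that its effect did not register. Compound 3 `COc1ccc(C(=O)c2sc(Nc3ccc(Cl)cc3)c(C(=O)O)c2C)cc1` differs from compound 2 by hydrogen in place of methyl on an oxygen next to a carbonyl group. Among the measured compounds shown here, with no measured pair showing such a change, no step size can be read off; the expectation is a change, if any, within the usual scatter. Compound 3 is estimated to give 5%, in the range 0% to 20%.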

Compound 3, a percentage reported as activity, at one concentration (the size of the read-out at that concentration, not a potency): "not active" (no number reported)
The entry for compound 3 holds no number; there is nothing to compare the estimate with.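

Compound 2 and compound 3 are both reported as not active in this assay with no number for either, so no step can be read between them. As far as these compounds go, whether changing methoxycarbonyl to carboxy alters the effect of a compound with a measurable read-out, such as compound 1, stays open. No other data bear on this result.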